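Benzyloxy variation on the shared core, compound 4

This account rests on a few compounds, and the source may have more. Where it says the series, first, only, none or still open, it means among the compounds named here.

Compound 2 `Cc1nn(-c2ncnc3nc[nH]c23)c2c1C(OCc1ccccc1F)CC(=O)N2` gives 4 nM in a functional assay on HEK293 cells for agonist activity at G-protein coupled receptor 39 (Homo sapiens), read by scintillation proximity assay and inositol phosphate accumulation, with a stated time of 75 min, in the presence of a further agent that is not named here; on this read-out higher numbers stand for an effect only at larger amounts of compound and lower numbers for an effect already at smaller amounts; compound 1 `Cc1nn(-c2ncnc3nc[nH]c23)c2c1C(C(=O)NCc1ccc(F)cc1)CC(=O)N2` gives 4 nM in this assay, and the two are level at the digits shown, together the lowest of the three numbers. Going by the values given here, compound 3 `Cc1nn(-c2ncnc3nc[nH]c23)c2c1C(c1ccc(OC(C)C)cc1)CC(=O)N2` gives 18 nM; the step of a 4.5-fold higher number from compound 2 to compound 3 (0.65 log units; beyond the scatter) is the only measured step, and it replaces the whole (2-fluorobenzyl)oxy group. Compound 4 `Cc1nn(-c2ncnc3nc[nH]c23)c2c1C(OCc1ccc(C#N)cc1)CC(=O)N2` differs from compound 2 by 4-cyanophenyl in place of 2-fluorophenyl on a saturated chain carbon bound to an oxygen on a saturated carbon, so the oxygen on a saturated carbon is retained and only the aromatic ring changes. Among the compounds with values here, no measured step tests this change directly; the step from compound 2 to compound 3 is of a different kind. Compound 4 is expected to stay close to compound 2, with the step of a 1.5-fold higher number from compound 2 to compound 4 (0.18 log units; within the scatter) near the scatter. The estimate for compound 4 is 6 nM, range 2 nM to 20 nM.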

Compound 4, half-maximal effective concentration: 4 nM
Compound 4: the middle estimate sits 1.5-fold (0.18 log units) above what was measured; measured number inside the range.
By their numbers in this assay, from the lowest: compounds 1, 2 and 4 (each within the scatter of the next); then compound 3.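

In this assay, the swap of 4-cyanophenyl for 2-fluorophenyl on a saturated chain carbon bound to an oxygen on a saturated carbon gives no change at the digits printed from compound 2 to compound 4 (within the scatter), so this position accepts a nitrile-bearing ring as well as a fluorine-bearing one. The (4-cyanobenzyl)oxy group in place of 4-isopropoxyphenyl on a saturated ring carbon gives a 4.5-fold lower number from compound 3 to compound 4 (0.65 log units; beyond the scatter), so a second benzyloxy compound now shows the same gap to compound 3. No supporting data bear on this result. Still open, going by these compounds, is whether a benzyl ring carrying an amine or a carboxylic acid, or a longer chain in place of the benzyl group, stays at this level.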